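The source may hold more compounds than are shown below. What is called first, only, known or untested is meant among the compounds shown, and "the series" means these compounds.

Of the compounds shown here, three have been measured in a functional assay on HEp-2 cells (Homo sapiens) for antiproliferative activity, read by MTT assay, with a stated time of 72 h; a higher number here means a weaker inhibitor, a lower number a stronger inhibitor. Compound 1 `O=c1c(SC(=S)N2CCCC2)coc2ccc(Cl)cc12` gives 26000 nM in this assay. Compound 2 `O=c1cc(CSC(=S)N2CCCCC2)oc2cc(Cl)ccc12` gives 1600 nM. Compound 3 `O=c1cc(CSC(=S)N2CCCC2)oc2ccccc12` gives 9100 nM, the second highest of the three numbers: the nearest number is that of compound 1, which lies higher by more than the usual scatter, and the furthest is that of compound 2, which lies lower by more than the scatter. Going by the values given here, compound 2 and compound 3 differ in more than one place, so no single step between them can be read off.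

Compound 4 `O=c1cc(CSC(=S)N2CCCCC2)oc2ccccc12` has not yet been measured. It differs from compound 3 in one place: piperidin-1-yl in place of pyrrolidin-1-yl on a thiocarbonyl carbon. Among the compounds with values here, no pair of measured compounds shows this change on its own, so its size is open. Compound 2, which carries the same six-membered ring on the thiocarbonyl carbon, gives the lowest number of the three, but it also differs from compound 3 on the shared core, so the ring change cannot be separated from that difference. A small step downward is expected for compound 4, possibly within the scatter, no large one. The step from compound 3 to compound 4 is estimated as a 1.8-fold lower number from compound 3 to compound 4 (0.26 log units; within the scatter). Compound 4 is expected to give about 5000 nM, with a range from 1800 nM to 14000 nM.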

Compound 4, half-maximal inhibitory concentration: 12000 nM
Beside the measured number, compound 4's estimate is 2.4-fold (0.38 log units) below it, and the stated range covers the measured number.
By their numbers in this assay, from the lowest: compound 2; then compounds 3 and 4 (each within the scatter of the next); then compound 1.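

In this assay, piperidin-1-yl in place of pyrrolidin-1-yl on a thiocarbonyl carbon gives a 1.3-fold higher number from compound 3 to compound 4 (0.12 log units; within the scatter) on the unchlorinated core, so at this position the six-membered ring cannot be told apart from the five-membered ring in this pair. Hydrogen in place of chloro on an aromatic carbon gives a 7.5-fold higher number from compound 2 to compound 4 (0.88 log units; beyond the scatter) with piperidin-1-yl held constant, which ties the low number of compound 2 to the chloro group and not to the ring it shares with compound 4. Nothing available bears on the reason for either step.

Going by these compounds, whether the chloro step holds with pyrrolidin-1-yl on the thiocarbonyl carbon remains open, and steps to compound 1 cannot be read, as it differs from each of the other compounds in more than one place. Also open, on these data alone, is how a morpholin-4-yl ring or a diethylamino group would compare on the thiocarbonyl carbon, and how fluoro or methoxy would compare with chloro on the aromatic carbon.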